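A few compounds are considered here, and "the series" means these few. Any claim that something is new, unique, unknown or untested is made for them only; others in the source may bear on it.

Measured in a functional assay on SW-620 cells (Homo sapiens) for cytotoxicity, read by sulforhodamine B assay, with a stated time of 48 h; a higher number here means a weaker inhibitor, a lower number a stronger inhibitor:
- Compound 1 `C[C@H]1CC[C@@H]2[C@@H](OC(=O)[C@]23CC(c2c(Cl)cccc2Cl)=NO3)[C@]2(C)C(=O)C=C[C@@]12O`: 43000 nM
- Compound 2 `C[C@H]1CC[C@@H]2[C@@H](OC(=O)[C@]23CC(c2ccccc2)=NO3)[C@]2(C)C(=O)C=C[C@@]12O`: 45400 nM
- Compound 3 `C[C@H]1CC[C@@H]2[C@@H](OC(=O)[C@]23CC(c2ccccc2[N+](=O)[O-])=NO3)[C@]2(C)C(=O)C=C[C@@]12O`: 40000 nM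

Compound 3 gives 40000 nM, a value within the usual scatter of those of compound 1 and compound 2, so the three cannot be ranked. The next molecule, compound 4 `C[C@H]1CC[C@@H]2[C@@H](OC(=O)[C@]23CC(c2ccc([N+](=O)[O-])cc2)=NO3)[C@]2(C)C(=O)C=C[C@@]12O`, has 4-nitrophenyl in place of 2-nitrophenyl on a carbon with a double bond to nitrogen.

Among the measured compounds shown here, three measured steps bear on this change, since all of them alter the group on that same carbon. Adding a nitro group gave a 1.1-fold lower number from compound 2 to compound 3 (0.05 log units; within the scatter). Replacing 2,6-dichlorophenyl gave a 1.1-fold higher number from compound 1 to compound 2 (0.02 log units; within the scatter) with phenyl and a 1.1-fold lower number from compound 1 to compound 3 (0.03 log units; within the scatter) with 2-nitrophenyl. Each step lies within the scatter, so these compounds show no response to the changes made so far. None of them carries 4-nitrophenyl, however, so the forecast goes beyond what has been tested.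

No step beyond the scatter is expected in this assay, and the estimated change is a 1.1-fold higher number from compound 3 to compound 4 (0.02 log units; within the scatter). For compound 4 the estimated value is 42000 nM, with an expected range of 22000 nM to 80000 nM.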

Compound 4, half-maximal inhibitory concentration: 9000 nM
The estimate for compound 4 lay 4.7-fold (0.67 log units) above the measured number, outside the stated range (below it).
By their numbers in this assay, from the lowest: compound 4; then compounds 3, 1 and 2 (each within the scatter of the next).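

In this assay, the same nitro group on the same phenyl ring gives a different result depending on where it sits: 4-nitrophenyl in place of 2-nitrophenyl gives a stronger inhibitor (a 4.4-fold lower number from compound 3 to compound 4 (0.65 log units; beyond the scatter)). Among the compounds shown here, the carbon bearing this ring therefore does respond to a change in its group, which the earlier compounds did not show, since 4-nitrophenyl stands out both against phenyl (a 5.0-fold lower number from compound 2 to compound 4 (0.70 log units; beyond the scatter)) and against 2,6-dichlorophenyl (a 4.8-fold lower number from compound 1 to compound 4 (0.68 log units; beyond the scatter)). No measurement shown here explains why the two nitrophenyl groups differ.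

On these data alone, it remains open whether this stronger result needs the nitro group itself or would also appear with another group in its place, as in 4-aminophenyl or 4-carboxyphenyl. The compounds shown also leave open how 3-nitrophenyl would compare.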